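A few compounds are considered here, and "the series" means these few. Any claim that something is new, unique, unknown or untested is made for them only; others in the source may bear on it.

Working notes on the series. Three compounds share the core of compound 2 `Oc1ccc(O)c(-c2cc(-c3ccccc3)nn2-c2ccccc2)c1`; in a functional assay on cells (Cancer cell lines, Homo sapiens) for cytotoxicity, read by sulforhodamine B assay, with a stated time of 48 h (on this read-out lower numbers stand for stronger inhibition of growth and higher numbers for weaker inhibition of growth), compound 2 gives 37700 nM, the highest of the three numbers. Within the data shown here, compound 3 `Oc1ccc(O)c(-c2cc(-c3ccc(Cl)cc3)nn2-c2ccccc2)c1` gives 8010 nM; the step of a 4.7-fold lower number from compound 2 to compound 3 (0.67 log units; beyond the scatter) is the only single-point change measured so far, and it concerns a different position. Compound 1 `COc1ccc(OC)c(-c2cc(-c3ccccc3)nn2-c2ccc(S(N)(=O)=O)cc2)c1`, which carries sulfamoyl together with two methoxy groups, gives 13600 nM, a lower number than compound 2, but the two differ in more than one place. Compound 4 `NS(=O)(=O)c1ccc(-n2nc(-c3ccccc3)cc2-c2cc(O)ccc2O)cc1` follows from compound 2 by sulfamoyl in place of hydrogen on an aromatic carbon. Among the measured compounds shown here, no measured step bears directly on this change; compound 1 hints that a lower number is possible. Compound 4 is expected near 15000 nM (range 5000 nM to 45000 nM), a step of a 2.5-fold lower number from compound 2 to compound 4 (0.40 log units; beyond the scatter) estimated, in direction of a lower number.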

Compound 4, concentration for 50% growth inhibition: 81300 nM
The estimate for compound 4 lay 5.4-fold (0.73 log units) below the measured number; measured number outside the range, above it.
By their numbers in this assay, from the lowest: compounds 3 and 1 (each within the scatter of the next); then compound 2; then compound 4.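

In this assay sulfamoyl in place of hydrogen on an aromatic carbon, para to a large group, gives a 2.2-fold higher number from compound 2 to compound 4 (0.33 log units; beyond the scatter) and so goes the opposite way to the hint from compound 1. With sulfamoyl held in place, 2,5-dihydroxyphenyl in place of 2,5-dimethoxyphenyl gives a 6.0-fold higher number from compound 1 to compound 4 (0.78 log units; beyond the scatter) as the larger listed change at this stage of the series. No measurement at hand gives a reason for either step. The effect of sulfamoyl alongside 2,5-dimethoxyphenyl remains open, since the shown compounds include no partner for compound 1 that differs only there. Also open, from the compounds shown here alone, is how an amine or a carboxylic acid at the same place would read.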